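From Compound 2 to Compound 4: a Change Without Precedent

The compounds below may be only part of what the source reports. "The series", "measured", "known", "first", "only" and "open" are said of these compounds alone.

Compound 1 `CCOc1ccc(NCc2nc3cc(OC)ccc3[n+]([O-])c2-c2ccccc2)cc1`: 80.7%
Compound 2 `Cc1c(C(=O)N=[N+]=[N-])[n+]([O-])c2cc(Cl)ccc2[n+]1[O-]`: 59.1%
Compound 3 `COc1ccc2c(c1)[n+]([O-])c(C(=O)N=[N+]=[N-])c(C)[n+]2[O-]`: 1.3%

In a functional assay on Ehrlich cells (Mus musculus) for cytotoxicity, read by trypan blue exclusion, with a stated time of 2 h, tested at 100 ug/mL (on this read-out lower numbers stand for a stronger effect and higher numbers for a weaker effect at the one concentration tested), compound 2 gives 59.1%, the second highest of the three numbers. Compound 1 stands higher by a gap beyond the scatter, and compound 3 stands far lower, also beyond the scatter. Among the compounds with values here, only one pair differs in a single place: a number 57.8 percentage points lower from compound 2 to compound 3 (beyond the scatter). Compound 4 `Cc1c(NC(=O)OC(C)C)[n+]([O-])c2cc(Cl)ccc2[n+]1[O-]` differs from compound 2 at another position: a group of 7 heavy atoms (4 carbon, 1 nitrogen, 2 oxygen; no ring) in place of a group of 5 heavy atoms (1 carbon, 3 nitrogen, 1 oxygen; no ring), on an aromatic carbon. Within the data shown here, the one measured step exchanges chloro for methoxy on an aromatic carbon elsewhere on the shared core, so it does not bear on the (isopropoxycarbonyl)amino group that enters here, and no other pair of measured compounds shows this exchange. With nothing to lean on, the expected step of a number 1.1 percentage points lower from compound 2 to compound 4 (within the scatter) is none beyond the scatter, held only loosely. Compound 4 is therefore expected to give about 58% in this assay, within a wide range from 15% to 92%.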

Compound 4, a percentage reported as activity, at one concentration (the size of the read-out at that concentration, not a potency): 90.6%
Estimate against measurement, compound 4: 32.6 percentage points below; low and high end bracket the measured number.
By their numbers in this assay, from the lowest: compound 3; then compound 2; then compounds 1 and 4 (each within the scatter of the next).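

Before compound 4, the only measured change was the exchange of chloro for methoxy elsewhere on the shared core; now the aromatic carbon next to the ring nitrogen proves to matter too, with a number 31.5 percentage points higher from compound 2 to compound 4 (beyond the scatter) in this assay. Higher numbers stand for a weaker effect here, so at the one concentration tested, (isopropoxycarbonyl)amino does not stand in for the group of 5 heavy atoms it replaces, and the effect is weaker with it. Nothing at hand says why the number moves.

As far as these compounds go, whether an amine or a carboxylic acid on this carbon would give a number nearer that of compound 2 or that of compound 4 remains open. Also open, from the compounds shown here alone, is whether methoxy in place of chloro would lower the number as sharply with (isopropoxycarbonyl)amino present as it does with the group in compound 2.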